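Swapping an oxygen for sulfur on a weak cytotoxic core

The compounds below may be only part of what the source reports. "The series", "measured", "known", "first", "only" and "open" are said of these compounds alone.

Of the compounds shown here, three share a fused two-ring core and have been tested in a functional assay on KB cells (Homo sapiens) for cytotoxicity; a lower number here means a stronger inhibitor, a higher number a weaker inhibitor. Compound 1, `NC(=S)c1cn(COCc2ccccc2)c2ncnc(N)c12`, gives only a limit of the assay, > 100000 nM. Compound 2, `NC(=S)c1cn(COCCO)c2ncnc(N)c12`, gives 115000 nM in this assay. Within the data shown here, the single measured step, a step that the limit leaves unreadable from compound 1 to compound 2, therefore cannot be read as a change of any size.

Compound 3, `Cn1cc(C(N)=O)c2c(N)ncnc21`, stands at the same limit in this assay, > 100000 nM. The new compound 4, `Cn1cc(C(=N)S)c2c(N)ncnc21`, differs from compound 3 by a group of 3 heavy atoms (1 carbon, 1 nitrogen, 1 sulfur; no ring) in place of a group of 3 heavy atoms (1 carbon, 1 nitrogen, 1 oxygen; no ring), on an aromatic carbon. Among the measured compounds shown here, no measured step compares a carbamoyl group with the entering group on this core, so nothing in the data bears directly on this change; the only evidence is the limit of > 100000 nM in this assay, at which 2 of the 3 values shown sit, and compound 2, whose side group matches that of compound 4, sits in the same weak region.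

Given that, compound 4 is expected to remain weak in this assay, with the estimated step that the limit leaves unreadable from compound 3 to compound 4 meaning no change beyond the scatter. The estimate for compound 4 in this assay is 120000 nM, with a range from 50000 nM to 300000 nM, and a real chance that only a limit is reported.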

Compound 4, half-maximal inhibitory concentration: 15000 nM
Beside the measured number, compound 4's estimate is 8.0-fold (0.90 log units) above it; the whole stated range lies above it.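

In this assay, putting the sulfur-bearing group on this aromatic carbon in place of carbamoyl gives an at least 6.6-fold lower number from compound 3 to compound 4 (0.82 log units; beyond the scatter), the first readable change among the compounds shown. The two groups hold the same number of heavy atoms and neither has a ring, yet sulfur stands where oxygen stood and the computed count of hydrogen-bond donors differs, so a swap this small on the shared core can move the result beyond the usual scatter. Compound 3 gives only a limit of the assay, > 100000 nM, so the step is a minimum rather than an exact size, and most of the data still sit at that ceiling: the limit of > 100000 nM in this assay, at which 2 of the 4 values shown sit.

From the compounds shown here alone, these compounds cannot separate the part played by sulfur from the part played by the changed donor count, and how a nitrile or a carboxylic acid would behave on this aromatic carbon remains open. Going by these compounds, it is also open whether the same swap would have a similar effect if a longer chain replaced the methyl group on the ring nitrogen.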